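Replacing a chlorophenyl amide with a pyrimidinyl amide

The source may hold more compounds than are shown below. What is called first, only, known or untested is meant among the compounds shown, and "the series" means these compounds.

Compound 1, `COc1ccc2nc(C)cc(OCC(=O)Nc3cc(C)ccc3C)c2c1`, > 100000 nM in a toxicity assay on HepG2 cells (Homo sapiens) for inhibition, read by CellTiter-Glo, with a stated time of 48 h (a higher number here means a weaker inhibitor, a lower number a stronger inhibitor), a limit.
Compound 2, `COc1ccc2nc(C)cc(OCC(=O)Nc3ccc(Br)c(C)c3)c2c1`, 15900 nM in this assay.
Compound 3, `COc1ccc2nc(C)cc(OCC(=O)Nc3ccc(Cl)cc3)c2c1`, > 100000 nM in this assay, a limit.

Compound 3 stands at the assay limit, the point named in the limit of > 100000 nM in this assay, at which 2 of the 3 values shown sit, and gives no number of its own. Among the measured steps, the change from compound 1 to compound 2 is an at least 6.2-fold lower number from compound 1 to compound 2 (0.79 log units; beyond the scatter), the change from compound 2 to compound 3 is an at least 6.2-fold higher number from compound 2 to compound 3 (0.79 log units; beyond the scatter), and the change from compound 1 to compound 3 is a step that the two limits leave unreadable from compound 1 to compound 3. Compound 4, `COc1ccc2nc(C)cc(OCC(=O)Nc3ccncn3)c2c1`, differs from compound 3 in one place: pyrimidin-4-yl in place of 4-chlorophenyl on an amide-type nitrogen. Going by the values given here, none of the measured steps exchanges a carbocyclic ring for a heteroaromatic one on the amide-type nitrogen, so no measured step bears directly on this change; the only firm point is that compound 3 itself sits at the limit. The step from compound 3 to compound 4 is therefore expected to be a number no higher from compound 3 to compound 4 (the limit leaves the size open), that is, no change that can be read against a limit. Compound 4 is expected to give about 100000 nM in this assay, within a range of 30000 nM to 300000 nM, most likely reported again as a limit.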

Compound 4, half-maximal inhibitory concentration: > 100000 nM
Compound 4 ended at the assay's limit (the forecaster's own chance of this, stated with the estimate: 75%); the middle value sits exactly at the limit.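

Going by these compounds alone, the move from 4-chlorophenyl to pyrimidin-4-yl on the amide-type nitrogen shows that a six-membered aromatic ring with 2 hetero atoms can stand at this position without giving a readable number in this assay, which the earlier compounds, all with carbon-only rings here, could not show. The one step that can be read is an at least 6.2-fold higher number from compound 2 to compound 4 (0.79 log units; beyond the scatter), so compound 2, with its 4-bromo-3-methylphenyl group, remains the only compound shown with a number of its own, while the steps to compound 4 from compound 3 and from compound 1 cannot be read, as both ends of each are limits. The result adds one more compound to those at the same point: the limit of > 100000 nM in this assay, at which 3 of the 4 values shown sit.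

On these data alone, how far compound 3 and compound 4 lie from each other, and whether the exchange of rings changes inhibition at all, stays unknown, as neither compound gives a number. Also open, as far as these compounds go, is what a 4-bromophenyl or a 3-methylphenyl group alone would give on this nitrogen, and whether a pyridin-4-yl ring or a ring bearing a bromine on the pyrimidine would move the value off the limit.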